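This account rests on a few compounds, and the source may have more. Where it says the series, first, only, none or still open, it means among the compounds named here.

Three compounds have been measured in an assay for inhibition of RAC-alpha serine/threonine-protein kinase (Homo sapiens), read by HTRF, with a stated time of 1 h; a higher number here means a weaker inhibitor, a lower number a stronger inhibitor:

Compound 1 `Cn1ncc(Cl)c1-c1cc(C(=O)N[C@@H]2CN[C@H](CC(O)CO)C[C@H]2c2ccc(Cl)c(Cl)c2)oc1Cl`: 3.79 nM
Compound 2 `Cn1ncc(Cl)c1-c1cc(C(=O)N[C@@H]2CN[C@H](CCCO)C[C@H]2c2ccc(Cl)c(Cl)c2)oc1Cl`: 2.56 nM
Compound 3 `Cn1ncc(Cl)c1-c1cc(C(=O)N[C@@H]2CN[C@H](CC(N)=O)C[C@H]2c2ccc(Cl)c(Cl)c2)oc1Cl`: 3.24 nM

All three share one core and differ only in a single side chain. Compound 3 gives the second highest number of the three, but its neighbours lie close on either side: the step of a 1.2-fold lower number from compound 1 to compound 3 (0.07 log units; within the scatter) and the step of a 1.3-fold higher number from compound 2 to compound 3 (0.10 log units; within the scatter) are both within the scatter, as is the step of a 1.5-fold lower number from compound 1 to compound 2 (0.17 log units; within the scatter) between the other two. On this evidence the side chain has been varied three ways without any change that can be told from noise.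

Compound 4 `Cn1ncc(Cl)c1-c1cc(C(=O)N[C@@H]2CN[C@H](CC(=O)NCC(O)CO)C[C@H]2c2ccc(Cl)c(Cl)c2)oc1Cl` continues the same theme. The change is 2,3-dihydroxypropyl in place of hydrogen on an amide-type nitrogen, so the carbamoyl of compound 3 grows into a (2,3-dihydroxypropyl)carbamoyl. The three measured steps all touch this same chain, all were within the scatter, and the new group repeats the dihydroxy motif of compound 1. The step in this assay is therefore expected to be small, a 1.2-fold higher number from compound 3 to compound 4 (0.09 log units; within the scatter), with no direction that can be called. Compound 4 is estimated at 4 nM, within a range from 1.5 nM to 12 nM.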

Compound 4, half-maximal inhibitory concentration: 3.13 nM
For compound 4 the middle estimate is 1.3-fold (0.11 log units) above the measured one, and the stated range covers the measured number.
By their numbers in this assay, from the lowest: compounds 2, 4, 3 and 1 (each within the scatter of the next).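

In this assay, the amide-type nitrogen of compound 3 carries a 2,3-dihydroxypropyl group in place of its hydrogen, a gain of 5 heavy atoms, and the outcome is a 1.0-fold lower number from compound 3 to compound 4 (0.02 log units; within the scatter). This is the first change shown on that nitrogen, and it extends the side chain without any shift that can be told from noise. Compared with the other two side chains, the result is the same, with a 1.2-fold higher number from compound 2 to compound 4 (0.09 log units; within the scatter) and a 1.2-fold lower number from compound 1 to compound 4 (0.08 log units; within the scatter), so all four compounds now sit within the scatter of one another, and nothing shown offers any explanation for how little the number responds.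

On these data alone, what stays open is whether any group at this place can move the number beyond the scatter, for example an amine or a carboxylic acid at the end of the chain, or a plain hydrocarbon chain with no oxygen or nitrogen. As far as these compounds go, all four compounds also share one core and are compared in this single assay, so it remains unknown whether they would stay this close on a different core or in a different test.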